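Three aryl variants measured, a fourth awaits its number

A few compounds are considered here, and "the series" means these few. Any claim that something is new, unique, unknown or untested is made for them only; others in the source may bear on it.

Three compounds built on a shared core differ only in the aryl group attached to a carbon with a double bond to nitrogen. Compound 1 `COc1ccc(OC)c(/C=N/NC(=O)Nc2ccc(Oc3ccnc(-c4nncn4CCN(C)C)c3)c(F)c2)c1` carries a 2,5-dimethoxyphenyl, compound 2 `COc1ccc(/C=N/NC(=O)Nc2ccc(Oc3ccnc(-c4nncn4CCN(C)C)c3)c(F)c2)c(OC)c1OC` a 2,3,4-trimethoxyphenyl and compound 3 `CN(C)CCn1cnnc1-c1cc(Oc2ccc(NC(=O)N/N=C/c3ccc(O)c(O)c3)cc2F)ccn1` a 3,4-dihydroxyphenyl. In a functional assay on NCI-H460 cells (Homo sapiens) for cytotoxicity, read by MTT assay, with a stated time of 72 h (a higher number here means a weaker inhibitor, a lower number a stronger inhibitor), compound 1 gives 2930 nM, compound 2 gives 1790 nM and compound 3 gives 1930 nM. Compound 2 has the lowest of the three numbers, yet the step of a 1.6-fold lower number from compound 1 to compound 2 (0.21 log units; within the scatter) and the step of a 1.1-fold higher number from compound 2 to compound 3 (0.03 log units; within the scatter) both stay within the scatter, as does the step of a 1.5-fold lower number from compound 1 to compound 3 (0.18 log units; within the scatter).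

Compound 4 `Cc1cc(/C=N/NC(=O)Nc2ccc(Oc3ccnc(-c4nncn4CCN(C)C)c3)c(F)c2)cc(C)c1O` has not yet been measured in this assay. Relative to compound 2 the change is 4-hydroxy-3,5-dimethylphenyl in place of 2,3,4-trimethoxyphenyl on a carbon with a double bond to nitrogen. All three measured steps concern exchanges of the aryl group at this same position, and none of them moved the number beyond the scatter, including the exchange of three methoxy groups for two hydroxyl groups on the way from compound 2 to compound 3. The step to compound 4 is therefore expected to be a 1.1-fold higher number from compound 2 to compound 4 (0.05 log units; within the scatter), with no clear direction. Compound 4 is estimated at 2000 nM, in a range from 900 nM to 4500 nM.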

Compound 4, half-maximal inhibitory concentration: 2010 nM
Compound 4: middle estimate off by 1.0-fold (0.00 log units), on the low side; low and high end bracket the measured number.
By their numbers in this assay, from the lowest: compounds 2, 3, 4 and 1 (each within the scatter of the next).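

In this assay the exchange of the 2,3,4-trimethoxyphenyl, with 12 heavy atoms, 0 hydrogen-bond donors and 3 hydrogen-bond acceptors, for the 4-hydroxy-3,5-dimethylphenyl, with 9 heavy atoms, 1 hydrogen-bond donor and 1 hydrogen-bond acceptor, gives a 1.1-fold higher number from compound 2 to compound 4 (0.05 log units; within the scatter) and so adds a group carrying methyl substituents to the set of aryl groups at this position. The step of a 1.0-fold higher number from compound 3 to compound 4 (0.02 log units; within the scatter) and the step of a 1.5-fold lower number from compound 1 to compound 4 (0.16 log units; within the scatter) also stay within the scatter, so the four compounds shown cannot be ordered at this position, whether the aryl group carries methoxy groups, hydroxyl groups alone, or a hydroxyl group with two methyl groups. No measurement is at hand that would explain this flat result.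

As far as these compounds go, all four groups are substituted phenyl rings, so it remains open whether a ring containing nitrogen, such as pyridyl, would leave the number equally unchanged. From the compounds shown here alone, it is equally open whether a phenyl ring bearing a carboxylic acid or an amine, or an alkyl chain in place of the ring, would produce a step beyond the scatter.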